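Thiophen-2-yl to thiophen-3-yl: working notes

The compounds below may be only part of what the source reports. "The series", "measured", "known", "first", "only" and "open" are said of these compounds alone.

In a functional assay for inhibition, with Homo sapiens as the target (a higher number here means a weaker inhibitor, a lower number a stronger inhibitor), compound 1 (`COc1cccc(Nc2nccc(-c3ccco3)n2)c1`) gives 400 nM, compound 2 (`COc1cccc(Nc2nccc(-c3ccccn3)n2)c1`) gives 200 nM and compound 3 (`COc1cccc(Nc2nccc(-c3cccs3)n2)c1`) gives 900 nM, the highest number of the three. Compound 4 (`COc1cccc(Nc2nccc(-c3ccsc3)n2)c1`) carries thiophen-3-yl in place of thiophen-2-yl on an aromatic carbon.

The measured changes at this place are a 2.0-fold lower number from compound 1 to compound 2 (0.30 log units; within the scatter), within the scatter, and the modest 2.3-fold higher number from compound 1 to compound 3 (0.35 log units; beyond the scatter) and a 4.5-fold higher number from compound 2 to compound 3 (0.65 log units; beyond the scatter). None of them tests a thiophene pair directly, so only a small change is anticipated. The expected step is a 1.5-fold lower number from compound 3 to compound 4 (0.18 log units; within the scatter), toward a lower number and probably within the scatter. For compound 4 the estimated value is 600 nM, with an expected range of 220 nM to 1600 nM.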

Compound 4, half-maximal inhibitory concentration: 1800 nM
For compound 4 the middle estimate is 3.0-fold (0.48 log units) below the measured one, and the stated range ends below it.
By their numbers in this assay, from the lowest: compounds 2 and 1 (each within the scatter of the next); then compounds 3 and 4 (each within the scatter of the next).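

In this assay the switch of attachment on the thiophene gives a 2.0-fold higher number from compound 3 to compound 4 (0.30 log units; within the scatter) and so does not separate thiophen-2-yl from thiophen-3-yl at this place. The distance from the furan-2-yl and pyridin-2-yl analogues remains for the new isomer, with a 9.0-fold higher number from compound 2 to compound 4 (0.95 log units; beyond the scatter) and a 4.5-fold higher number from compound 1 to compound 4 (0.65 log units; beyond the scatter) as the two steps. No supporting data bear on the reason for this result.

Open, as far as these compounds go, is whether pyridin-3-yl or furan-3-yl would show a similarly small shift of attachment. Also open, from the compounds shown here alone, is whether an amine or a carboxylic acid on the thiophene would move the number at all.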